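This account rests on a few compounds, and the source may have more. Where it says the series, first, only, none or still open, it means among the compounds named here.

In an assay on isolated protein for inhibition of Amine oxidase [flavin-containing] A (Homo sapiens), read by fluorescence, with a stated time of 20 min (on this read-out higher numbers stand for weaker inhibition and lower numbers for stronger inhibition), three compounds built on a shared core have been measured so far. Compound 1 `CC/C(C)=N\Nc1nc(-c2cccc([N+](=O)[O-])c2)cs1` gives 20500 nM in this assay. Compound 2 `CCC/C(C)=N\Nc1nc(-c2cccc([N+](=O)[O-])c2)cs1` gives 38000 nM. Compound 3 `CCCCC/C(CC)=N\Nc1nc(-c2cccc([N+](=O)[O-])c2)cs1` gives 7150 nM, the lowest of the three numbers, and its distance to each of the other two lies beyond the scatter. Compound 2 and compound 1 differ in one place: hydrogen in place of methyl on a saturated chain carbon, two bonds along the chain from a carbon with a double bond to nitrogen That change made a step of a 1.9-fold lower number from compound 2 to compound 1 (0.27 log units; within the scatter). The difference between the core of compound 2 and the core of compound 3 is not broken down here.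

Compound 4 `CCCC/C(CC)=N\Nc1nc(-c2cccc([N+](=O)[O-])c2)cs1` has not yet been measured in this assay. Among the measured compounds shown here, it differs from compound 3 as follows: hydrogen in place of methyl on a saturated chain carbon, four bonds along the chain from a carbon with a double bond to nitrogen This is the same kind of change as the one between compound 2 and compound 1, but not the same change, since the place differs: there the methyl sat on a saturated chain carbon two bonds along the chain from a carbon with a double bond to nitrogen, here it sits four bonds along that chain. Because the step of a 1.9-fold lower number from compound 2 to compound 1 (0.27 log units; within the scatter) stayed within the scatter, a similarly small step is expected here, estimated as a 1.2-fold higher number from compound 3 to compound 4 (0.08 log units; within the scatter). Compound 4 is therefore expected to give about 8500 nM in this assay, with the likely range for compound 4 running from 3500 nM to 20000 nM. The measured number will show whether this expectation holds.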

Compound 4, half-maximal inhibitory concentration: 6030 nM
Compound 4: the middle estimate sits 1.4-fold (0.15 log units) above what was measured; the measured number falls inside the stated range.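

In this assay, hydrogen in place of methyl on a saturated chain carbon, four bonds along the chain from a carbon with a double bond to nitrogen, gave a 1.2-fold lower number from compound 3 to compound 4 (0.07 log units; within the scatter), so on this core the change did not move the number beyond the scatter. This does not show that the change is without effect throughout the series: only two cores are shown, the place of the change differs between them, and steps this small cannot fix a size to carry over to a further core. What the two cases do support is a narrower statement, that this kind of change stayed small on both cores and that the two steps cannot be told apart: the same change on two cores in this assay, a 1.9-fold lower number (0.27 log units; within the scatter) from compound 2 to compound 1 and a 1.2-fold lower number (0.07 log units; within the scatter) from compound 3 to compound 4, 1.6-fold (0.19 log units) apart, within the scatter of two such steps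

The compounds shown leave open whether a longer chain at this place, or a chain ending in an amine or a carboxylic acid, would shift the number beyond the scatter. They also leave open whether the step would stay this small if a hydroxyl group or a cyclopropyl ring took the place of the methyl.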